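Shrinking a ring to a bare amino group

The source may hold more compounds than are shown below. What is called first, only, known or untested is meant among the compounds shown, and "the series" means these compounds.

Measured compounds:
compound 1, `CN(c1ccc2cc(NC(=O)CCc3ccc(C(F)(F)F)cc3)ccc2n1)C1CCCCC1`, 1200 nM
compound 2, `O=C(CCc1ccc(C(F)(F)F)cc1)Nc1ccc2nc(N3CCCCC3)ccc2c1`, 110 nM

Both compounds were tested in a functional assay on HEK293 cells for activation of melanin-concentrating hormone receptor 1 (Rattus norvegicus), read by inositol phosphate accumulation; a higher number here means that more compound is needed for the effect, a lower number that less compound is needed. Compound 2 gives the lowest of the two numbers; the nearest is compound 1, which gives 1200 nM. Among the compounds with values here, the one step between them, an 11-fold lower number from compound 1 to compound 2 (1.04 log units; beyond the scatter), comes from putting piperidin-1-yl in place of cyclohexyl(methyl)amino on an aromatic carbon.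

The next compound, compound 3, `Nc1ccc2cc(NC(=O)CCc3ccc(C(F)(F)F)cc3)ccc2n1`, differs from compound 2 in this way: amino in place of piperidin-1-yl on an aromatic carbon. The group sits on an aromatic carbon next to the ring nitrogen of the shared core.

Within the data shown here, the only measured step bears on the same position, and it shows that even a modest reshaping of the group there moved the number by a large amount. Trading the whole six-membered ring for a single nitrogen is a far bigger change, so a large shift toward a higher number in this assay is expected, though the direction rests on one step only. For compound 3 the expected step is a 14-fold higher number from compound 2 to compound 3 (1.13 log units; beyond the scatter). Compound 3 is therefore estimated at 1500 nM, within a range from 300 nM to 8000 nM.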

Compound 3, half-maximal effective concentration: 720 nM
For compound 3 the middle estimate is 2.1-fold (0.32 log units) above the measured one; measured number inside the range.
By their numbers in this assay, from the lowest: compound 2; then compounds 3 and 1 (each within the scatter of the next).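

Replacing the piperidin-1-yl ring with amino gives in this assay a 6.5-fold higher number from compound 2 to compound 3 (0.82 log units; beyond the scatter), so the bare amino group does not preserve the lower number seen with the ring at this position. The comparison with the bulkier open group gives a 1.7-fold lower number from compound 1 to compound 3 (0.22 log units; within the scatter), which places the amino and cyclohexyl(methyl)amino compounds within the scatter of each other, even though they carry very different groups on the aromatic carbon next to the ring nitrogen; across these three compounds, the number therefore does not run in step with how much is attached there, and only compound 2 stands apart. Nothing measured here gives a reason for these differences.

The compounds shown leave open whether the advantage of compound 2 belongs to the six-membered ring itself or would survive in a smaller pyrrolidine ring or a morpholine ring, which has an oxygen in place of one ring carbon. They also leave open what a simple open dimethylamino group would do at this position, which would help separate the effect of the ring from that of a fully substituted nitrogen.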